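A few compounds are considered here, and "the series" means these few. Any claim that something is new, unique, unknown or untested is made for them only; others in the source may bear on it.

Of the compounds shown here, three sharing one core have been tested in a functional assay on HCT-116 cells (Homo sapiens) for inhibition; on this read-out higher numbers stand for weaker inhibition and lower numbers for stronger inhibition. Compound 1 `C=CNCc1cc(-c2c(C(=O)NCC)noc2-c2cc(C(C)C)c(O)cc2O)on1` gives 121 nM, compound 2 `CCNC(=O)c1noc(-c2cc(C(C)C)c(O)cc2O)c1-c1cc(CNCCO)no1` gives 111 nM, and compound 3 `CCNC(=O)c1noc(-c2cc(C(C)C)c(O)cc2O)c1-c1cc(CN2CCCC2)no1` gives 51 nM, the lowest number of the three. Compound 4 `CCNC(=O)c1noc(-c2cc(C(C)C)c(O)cc2O)c1-c1cc(C(=O)NC)no1` differs from compound 3 by a larger swap: methylcarbamoyl in place of (pyrrolidin-1-yl)methyl on an aromatic carbon. In words, methylcarbamoyl stands in place of (pyrrolidin-1-yl)methyl on an aromatic carbon.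

The closest evidence comes from the three measured steps. The step of a 1.1-fold lower number from compound 1 to compound 2 (0.04 log units; within the scatter) lies within the scatter, while a 2.4-fold lower number from compound 1 to compound 3 (0.38 log units; beyond the scatter) and a 2.2-fold lower number from compound 2 to compound 3 (0.34 log units; beyond the scatter) are both modest. Each of these swaps only the group on the saturated chain carbon, whereas here the whole (pyrrolidin-1-yl)methyl leaves, so they guide the estimate only loosely. Compound 3 lost its modest lead over neither neighbour in these steps, and leaving pyrrolidin-1-yl behind is expected to give back a step of similar size in this assay, towards a higher number. The expected step is a 2.2-fold higher number from compound 3 to compound 4 (0.33 log units; beyond the scatter). Compound 4 is expected at 110 nM, with an estimated range of 35 nM to 350 nM.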

Compound 4, half-maximal inhibitory concentration: 124 nM
Compound 4: middle estimate off by 1.1-fold (0.05 log units), on the low side; the range from low to high includes it.
By their numbers in this assay, from the lowest: compound 3; then compounds 2, 1 and 4 (each within the scatter of the next).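

Compound 4 is the first compound shown in which the group on this aromatic carbon of the five-membered aromatic ring has no saturated chain carbon carrying an amine, and in this assay replacing (pyrrolidin-1-yl)methyl with methylcarbamoyl gives a 2.4-fold higher number from compound 3 to compound 4 (0.39 log units; beyond the scatter), a modest change. The amide also stands level with both open-chain amines, with a 1.1-fold higher number from compound 2 to compound 4 (0.05 log units; within the scatter) and a 1.0-fold higher number from compound 1 to compound 4 (0.01 log units; within the scatter), so among the four compounds only compound 3 stands apart, and this position accepts an amide as well as these two amines. Nothing measured here accounts for these differences.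

From the compounds shown here alone, it remains open whether the edge of compound 3 depends on its ring or on its amine nitrogen, which piperidin-1-ylmethyl and dimethylaminomethyl groups could help separate. A carboxylic acid or a dimethylcarbamoyl group at this position would show how far the methylcarbamoyl result extends.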